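A Ring Opened Toward an Amide-Bearing Chain

A few compounds are considered here, and "the series" means these few. Any claim that something is new, unique, unknown or untested is made for them only; others in the source may bear on it.

Compound 1 `CC(C)=CCc1cc(C(=O)Nc2cc3ccc(OCC4CCCNC4)c(C)c3oc2=O)ccc1O` carries a piperidin-3-yl group on the chain that leaves the aromatic oxygen. For the measured compounds named here, in a functional assay on MCF7 cells (Homo sapiens) for antiproliferative activity (on this read-out lower numbers stand for stronger inhibition and higher numbers for weaker inhibition), compound 1 gives 790 nM, the lowest of the three numbers measured so far. Compound 2 `CCNCCCOc1ccc2cc(NC(=O)c3ccc(O)c(CC=C(C)C)c3)c(=O)oc2c1C` gives 980 nM, and compound 3 `CCN(C)CCCOc1ccc2cc(NC(=O)c3ccc(O)c(CC=C(C)C)c3)c(=O)oc2c1C` gives 2190 nM. The step of a 1.2-fold higher number from compound 1 to compound 2 (0.09 log units; within the scatter) shows that opening the ring to a chain bearing a secondary amine barely moves the read-out, whereas a 2.8-fold higher number from compound 1 to compound 3 (0.44 log units; beyond the scatter) and a 2.2-fold higher number from compound 2 to compound 3 (0.35 log units; beyond the scatter) show a modest loss once that amine carries a methyl.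

Compound 4 `CC(C)=CCc1cc(C(=O)Nc2cc3ccc(OCCCNCC(N)=O)c(C)c3oc2=O)ccc1O` differs from compound 1 by 2-((carbamoylmethyl)amino)ethyl in place of piperidin-3-yl on a saturated chain carbon bound to an oxygen on an aromatic ring. Going by the values given here, this resembles the change to compound 2, in that the ring opens to a chain with a secondary amine, but the chain now ends in a carbamoyl group, for which no measured step gives guidance. The step to compound 2 being within the scatter, and the only loss beyond it arising at a methylated amine, compound 4 is expected to stand near compound 1 in this assay, with a 1.4-fold higher number from compound 1 to compound 4 (0.14 log units; within the scatter) as the estimated step. Compound 4 is therefore estimated at 1100 nM, within 500 nM to 2600 nM.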

Compound 4, half-maximal inhibitory concentration: 1460 nM
Beside the measured number, compound 4's estimate is 1.3-fold (0.12 log units) below it, within the range that was stated.
By their numbers in this assay, from the lowest: compounds 1, 2, 4 and 3 (each within the scatter of the next, the first and the last beyond it).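

In this assay, the chain ending in a carbamoyl group cannot be separated from any earlier compound: the result gives a 1.8-fold higher number from compound 1 to compound 4 (0.27 log units; within the scatter), a 1.5-fold higher number from compound 2 to compound 4 (0.17 log units; within the scatter) and a 1.5-fold lower number from compound 3 to compound 4 (0.18 log units; within the scatter). Compounds 1 and 3 differ beyond the scatter, yet compound 4 lies within the scatter of both, so the carbamoyl-bearing chain adds a third acyclic chain at this position without a clear step from any neighbour. No measurement at hand accounts for this result.

The compounds shown leave open whether a carboxylic acid or a nitrile in place of the carbamoyl group would stay within this range. They also leave open whether a longer chain between the amine and the carbamoyl group, or a methyl on that amine, would move the read-out beyond the scatter.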